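Naphthalen-2-yl in place of fluorophenyl: cytotoxicity in C8166 cells

The source may report more compounds than this note shows. Statements on the series, on what has been measured and on what is new or still open speak of the compounds shown alone.

Three compounds sharing one core have been examined in an ADME assay on C8166 cells (Homo sapiens) for cytotoxicity, read by MTT assay; a lower number here means that less compound is tolerated, a higher number that more compound is tolerated. Compound 1 `Cc1cc(S(N)(=O)=O)ccc1NC(=O)COc1ccc(Cl)cc1C(O)c1cccc(F)c1` gives 37600 nM. Compound 2 `Cc1ccc(C(O)c2cc(Cl)ccc2OCC(=O)Nc2ccc(S(N)(=O)=O)cc2C)c(C)c1` gives 26400 nM, and compound 3 `Cc1ccc(C)c(C(O)c2cc(Cl)ccc2OCC(=O)Nc2ccc(S(N)(=O)=O)cc2C)c1` gives 35500 nM. Among the measured compounds shown here, of the three numbers, the one for compound 1 is the largest, yet neither gap away from it reaches beyond the scatter: there is a 1.4-fold lower number from compound 1 to compound 2 (0.15 log units; within the scatter) and a 1.1-fold lower number from compound 1 to compound 3 (0.02 log units; within the scatter), and between the two dimethylphenyl analogues a 1.3-fold higher number from compound 2 to compound 3 (0.13 log units; within the scatter).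

Compound 4 `Cc1cc(S(N)(=O)=O)ccc1NC(=O)COc1ccc(Cl)cc1C(O)c1ccc2ccccc2c1` is not yet measured. It differs from compound 1 by naphthalen-2-yl in place of 3-fluorophenyl on a saturated chain carbon bound to an aromatic carbon and an oxygen on a saturated carbon. For the measured compounds named here, the steps that bear on it are the two exchanges of the 3-fluorophenyl group in compound 1 for a dimethylphenyl group, each of which left the number within the scatter. A ring enlargement at the same place is a somewhat different change, but nothing in these three compounds points to a move beyond the scatter in either direction, so compound 4 is expected to show a 1.3-fold lower number from compound 1 to compound 4 (0.10 log units; within the scatter). Compound 4 is therefore estimated at 30000 nM, with a range from 14000 nM to 60000 nM.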

Compound 4, half-maximal cytotoxic concentration: 15700 nM
The estimate for compound 4 lay 1.9-fold (0.28 log units) above the measured number; the range from low to high includes it.
By their numbers in this assay, from the lowest: compounds 4, 2, 3 and 1 (each within the scatter of the next, the first and the last beyond it).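

In this assay, among the compounds shown here, there is a 2.4-fold lower number from compound 1 to compound 4 (0.38 log units; beyond the scatter) and a 2.3-fold lower number from compound 3 to compound 4 (0.35 log units; beyond the scatter) at this saturated chain carbon, the first steps at this place to lie beyond the scatter, though both are modest. The exchange does not set naphthalen-2-yl apart from every group tried here: there is a 1.7-fold lower number from compound 2 to compound 4 (0.23 log units; within the scatter) as well, so the 2,4-dimethylphenyl group of compound 2 cannot be told from it. Nothing in the information available accounts for these steps.

The compounds shown leave open whether the step follows from the second aromatic ring or from the loss of the fluorine. They also leave open how naphthalen-1-yl or a saturated ring such as cyclohexyl would read at this carbon.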